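The compounds below may be only part of what the source reports. "The series", "measured", "known", "first", "only" and "open" are said of these compounds alone.

Compound 1 `COc1ccc(-c2cc3ccccc3nc2/C=C/C(=O)c2ccccc2)cc1`: 860 nM
Compound 2 `COc1ccc(C(=O)/C=C/c2nc3ccccc3cc2-c2ccc(OC)cc2)cc1`: 7540 nM
Compound 3 `COc1ccc(-c2cc3ccccc3nc2/C=C/C(=O)c2ccc(OC)cc2OC)cc1`: 3210 nM

In a functional assay on MDA-MB-231 cells (Homo sapiens) for antiproliferative activity, read by XTT assay, with a stated time of 72 h (a higher number here means a weaker inhibitor, a lower number a stronger inhibitor), compound 3 stands second highest of the three numbers; the step of a 3.7-fold higher number from compound 1 to compound 3 (0.57 log units; beyond the scatter) and the step of a 2.3-fold lower number from compound 2 to compound 3 (0.37 log units; beyond the scatter) mark its distance from the other two. Compound 4 `COc1ccc(-c2cc3ccccc3nc2/C=C/C(=O)c2ccc(OC)c(OC)c2)cc1` differs from compound 3 by 3,4-dimethoxyphenyl in place of 2,4-dimethoxyphenyl on a carbonyl carbon. Going by the values given here, no measured step rearranges the methoxy groups on that ring: the step of a 3.7-fold higher number from compound 1 to compound 3 (0.57 log units; beyond the scatter) shows what introducing the 2,4-dimethoxyphenyl did, and the steps of an 8.8-fold higher number from compound 1 to compound 2 (0.94 log units; beyond the scatter) and a 2.3-fold lower number from compound 2 to compound 3 (0.37 log units; beyond the scatter) concern other methoxy groups. The change is therefore expected to produce a step within the scatter, a 1.1-fold higher number from compound 3 to compound 4 (0.04 log units; within the scatter), perhaps leaning slightly toward a weaker inhibitor. Compound 4 is estimated at 3500 nM, in a range from 1300 nM to 9000 nM.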

Compound 4, half-maximal inhibitory concentration: 4790 nM
Compound 4: middle estimate off by 1.4-fold (0.14 log units), on the low side, within the range that was stated.
By their numbers in this assay, from the lowest: compound 1; then compounds 3, 4 and 2 (each within the scatter of the next, the first and the last beyond it).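

In this assay, rearranging the methoxy groups on the ring at the carbonyl carbon gives a 1.5-fold higher number from compound 3 to compound 4 (0.17 log units; within the scatter) and so leaves 2,4-dimethoxyphenyl and 3,4-dimethoxyphenyl indistinguishable here. The added methoxy group, with a 1.6-fold lower number from compound 2 to compound 4 (0.20 log units; within the scatter) in this assay, also stays within the scatter. Replacing phenyl gives a 5.6-fold higher number from compound 1 to compound 4 (0.75 log units; beyond the scatter) and thus a second dimethoxyphenyl ring whose number lies beyond the scatter from the phenyl compound. From the compounds shown here alone, whether an amine or a carboxylic acid on this ring would bring the number back towards that of the phenyl compound remains open. No evidence at hand bears on these steps.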